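Methyl to Methoxy on a Fused Core, Cytotoxicity Unchanged

A few compounds are considered here, and "the series" means these few. Any claim that something is new, unique, unknown or untested is made for them only; others in the source may bear on it.

Compound 1 `Cc1cccc2c(NCc3ccco3)nc(NC(C)C)nc12` and compound 2 `Cc1ccc2c(NCc3ccco3)nc(NC(C)C)nc2c1` are built from the same atoms, but the difference between the two cores is not broken down here. Compound 3 `COc1cccc2c(NCc3ccco3)nc(NC(C)C)nc12` is compound 1 with methoxy in place of methyl on an aromatic carbon. Compound 4 `COc1ccc2c(NCc3ccco3)nc(NC(C)C)nc2c1` is compound 2 with the same kind of change, (methoxy in place of methyl on an aromatic carbon), though the place differs: meta and para to a fused ring rather than ortho and meta.

In an ADME assay on J774.A1 cells (Mus musculus) for cytotoxicity, read by MTT assay, with a stated time of 72 h (on this read-out higher numbers stand for an effect only at larger amounts of compound and lower numbers for an effect already at smaller amounts), compound 1 reaches only a limit, > 33000 nM. Compound 2 also reaches only a limit in this assay, > 33000 nM. Compound 3 gives 30000 nM, so the change gives an at least 1.1-fold lower number from compound 1 to compound 3 (0.04 log units; that floor lies within the scatter), resting on (the limit of > 33000 nM in this assay, at which 2 of the 3 values shown sit).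

For compound 4 the expected step is a number no higher from compound 2 to compound 4 (the limit leaves the size open), because the same kind of change gave an at least 1.1-fold lower number from compound 1 to compound 3 (0.04 log units; that floor lies within the scatter). Compound 4 is therefore estimated at 33000 nM, between 15000 nM and 70000 nM.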

Compound 4, half-maximal effective concentration: 16000 nM
Beside the measured number, compound 4's estimate is 2.1-fold (0.31 log units) above it; the measured number falls inside the stated range.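

On the core of compound 2, methoxy in place of methyl moves the number in this assay by a step beyond the usual scatter, an at least 2.0-fold lower number from compound 2 to compound 4 (0.31 log units; beyond the scatter). On the core of compound 1 the printed floor of the step stays within that scatter, so the change is not shown to act with equal size on both cores, nor with different size: the same change on two cores in this assay, an at least 1.1-fold lower number (0.04 log units; that floor lies within the scatter) from compound 1 to compound 3 and an at least 2.0-fold lower number (0.31 log units; beyond the scatter) from compound 2 to compound 4; the limit leaves it open whether they differ. Compound 1 and compound 2 each stand only at a limit of the assay, so neither step has a fixed size: the limit of > 33000 nM in this assay, at which 2 of the 4 values shown sit.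

The compounds shown leave open how an amine, a carboxylic acid or a longer chain such as ethoxy on the same aromatic carbon would read in this assay.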